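A few compounds are considered here, and "the series" means these few. Any claim that something is new, unique, unknown or untested is made for them only; others in the source may bear on it.

Measured so far in a functional assay on NCI-H460 cells (Homo sapiens) for cytotoxicity, read by MTT assay, with a stated time of 72 h; on this read-out lower numbers stand for stronger inhibition and higher numbers for weaker inhibition: compound 1 `CN(C)CCn1cnnc1-c1cc(Oc2ccc(NC(=O)N/N=C/c3ccc(Cl)cc3Cl)cc2F)ccn1` gives 130 nM; compound 2 `CN(C)CCn1cnnc1-c1cc(Oc2ccc(NC(=O)N/N=C/c3cccc(Cl)c3Cl)cc2F)ccn1` gives 72 nM; compound 3 `CN(C)CCn1cnnc1-c1cc(Oc2ccc(NC(=O)N/N=C/c3ccc(O)cc3)cc2F)ccn1` gives 1780 nM.

On these three numbers compound 1 stands second highest; its nearest neighbour is compound 2, its furthest compound 3. The step of a 1.8-fold lower number from compound 1 to compound 2 (0.26 log units; within the scatter) lies within the scatter, while a 14-fold higher number from compound 1 to compound 3 (1.14 log units; beyond the scatter) is a large loss. Compound 4 `CN(C)CCn1cnnc1-c1cc(Oc2ccc(NC(=O)N/N=C/c3ccc(F)cc3Cl)cc2F)ccn1` differs from compound 1 by fluoro in place of chloro on an aromatic carbon, a change on an aromatic carbon meta to a chloro group and para to a large group. For the measured compounds named here, no measured step swaps one halogen for another at this position; the nearest analogue, the step from compound 1 to compound 2, shows that rearranging the chloro groups changes little, whereas only the loss of both chloro groups, as in compound 3, costs much. A small step is therefore expected in this assay, perhaps a slight weakening. For compound 4 the estimate is 180 nM (range 75 nM to 450 nM), an expected step of a 1.4-fold higher number from compound 1 to compound 4 (0.14 log units; within the scatter).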

Compound 4, half-maximal inhibitory concentration: 720 nM
Compound 4: the middle estimate sits 4.0-fold (0.60 log units) below what was measured, outside the stated range (above it).
By their numbers in this assay, from the lowest: compounds 2 and 1 (each within the scatter of the next); then compound 4; then compound 3.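

In this assay this position proves sensitive to the halogen: fluoro in place of chloro brings a 5.5-fold higher number from compound 1 to compound 4 (0.74 log units; beyond the scatter) and, against the other dichlorophenyl compound, the 2-chloro-4-fluorophenyl group gives a 10-fold higher number from compound 2 to compound 4 (1.00 log units; beyond the scatter). Compound 4 still keeps an edge over the 4-hydroxyphenyl compound, with a 2.5-fold lower number from compound 3 to compound 4 (0.39 log units; beyond the scatter). No measured evidence here accounts for the loss. The compounds shown leave open how bromo, methyl or methoxy would fare at this position. They also leave open whether fluoro would cost as much with the remaining chloro group elsewhere on the ring.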